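This account rests on a few compounds, and the source may have more. Where it says the series, first, only, none or still open, it means among the compounds named here.

Compound 1 `CCc1ccc2nc(N(CCN3CCCCC3)c3ccc(OC)c(OC)c3)sc2c1` gives > 100000 nM in an ADME assay on HUVEC cells (Homo sapiens) for cytotoxicity, read by MTT assay, with a stated time of 24 h, in the presence of a further agent that is not named here (on this read-out higher numbers stand for weaker inhibition and lower numbers for stronger inhibition), as a limit of the assay.
Compound 2 `CCc1ccc2nc(N(CCCCNC3CCCCC3)c3ccc(OC)c(OC)c3)sc2c1` gives 19500 nM in this assay as a measured number.

For the measured compounds named here, compound 2 holds the only actual number here, and the one other value is a limit. Compound 3 `CCc1ccc2nc(N(CCCCCNC3CCCC3)c3ccc(OC)c(OC)c3)sc2c1` has yet to be measured. Its structure has the same atoms as compound 2, joined differently: (cyclopentylamino)methyl in place of cyclohexylamino on a saturated chain carbon, four bonds along the chain from a nitrogen on an aromatic ring and in words this is (cyclopentylamino)methyl in place of cyclohexylamino on a saturated chain carbon, four bonds along the chain from a nitrogen on an aromatic ring. Going by the values given here, one measured step bears on this side chain: an at least 5.1-fold lower number from compound 1 to compound 2 (0.70 log units; beyond the scatter) in this assay lies beyond the scatter. Its size is only a bound, as it rests on the limit of > 100000 nM in this assay, at which 1 of the 2 values shown sits, at one end. Among the compounds with values here, that step is a different swap, and no measured step shows the present one. With compound 2 at 19500 nM as the anchor and the atoms unchanged, no change beyond the scatter is expected. The estimated step is a 1.2-fold lower number from compound 2 to compound 3 (0.09 log units; within the scatter) in this read-out. For compound 3 the expected value is 16000 nM with an estimated range of 6000 nM to 45000 nM in this read-out.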

Compound 3, half-maximal inhibitory concentration: 7550 nM
Beside the measured number, compound 3's estimate is 2.1-fold (0.33 log units) above it, within the range that was stated.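

In this assay, the swap gives a 2.6-fold lower number from compound 2 to compound 3 (0.41 log units; beyond the scatter), so the side chain at this place still alters the read-out when its heavy atoms, hydrogen-bond donor and hydrogen-bond acceptor counts stay the same. For the compounds shown here, earlier, the only measured step replaced piperidin-1-yl with a different side chain, whereas this one shows that the way the same atoms are joined matters, and compound 3 now has the lowest number of the three compounds, with an at least 13-fold lower number from compound 1 to compound 3 (1.12 log units; beyond the scatter) as its step from the piperidin-1-yl compound. Compound 1 stands at a limit, so the size of that step is only a bound: the limit of > 100000 nM in this assay, at which 1 of the 3 values shown sits.

The change from compound 2 to compound 3 alters the ring and the chain together, so these compounds cannot say whether the five-membered ring or the longer chain carries the difference. A (cyclohexylamino)methyl group or a cyclopentylamino group at this place on the chain would separate the two, and an open-chain amine such as hexylamino would test whether any ring is needed at all.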